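The source may report more compounds than this note shows. Statements on the series, on what has been measured and on what is new or still open speak of the compounds shown alone.

The two measured compounds and their values:
compound 1 `CC(C)(C)c1cc(NC(=O)Nc2ccc(Cl)cc2)n(-c2ccc(S(C)(=O)=O)cc2)n1`, 5.2 degrees C
compound 2 `CC(C)(C)c1cc(NC(=O)Nc2ccc(Cl)cc2)n(-c2ccc(N)cc2)n1`, 5.6 degrees C

Within the data shown here, in an assay on isolated protein for inhibition of STE20-like serine/threonine-protein kinase (Homo sapiens), read by thermal shift assay, tested at 10 uM (on this read-out higher numbers stand for stronger stabilisation of the target against heat and lower numbers for weaker stabilisation of the target), compound 2 gives 5.6 degrees C. The only other number belongs to compound 1, which gives 5.2 degrees C. The step of a number 0.40 degrees C higher from compound 1 to compound 2 (within the scatter) lies within the scatter, so neither compound can be called the stronger stabiliser. Compound 3 `CC(C)(C)c1cc(NC(=O)Nc2ccc(Cl)cc2)n(-c2ccc(NC(=O)C3CC3)cc2)n1` differs from compound 2 by cyclopropylcarbonyl in place of hydrogen on a nitrogen on an aromatic ring. Among the measured compounds shown here, no measured step touches this nitrogen in that way; the single known step exchanged a whole group on the aromatic ring and moved the number only within the scatter, which is a slender basis for the present change. For compound 3 the expected step of a number 0.10 degrees C lower from compound 2 to compound 3 (within the scatter) is therefore no movement beyond the scatter, in either direction, with a wide margin of doubt. Compound 3 is thus estimated at 5.5 degrees C, within a range from 3.5 degrees C to 7.5 degrees C.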

Compound 3, shift of the target's melting temperature: 4.1 degrees C
Compound 3: middle estimate off by 1.4 degrees C, on the high side, and the stated range covers the measured number.
By their numbers in this assay, from the lowest: compound 3; then compounds 1 and 2 (each within the scatter of the next).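

Among these compounds, this is the first change on this aromatic ring to move the number beyond the scatter: in this assay, cyclopropylcarbonyl in place of hydrogen on the nitrogen gives a number 1.5 degrees C lower from compound 2 to compound 3 (beyond the scatter) in the melting temperature shift. Measured against the methylsulfonyl compound, (cyclopropylcarbonyl)amino on the same aromatic carbon gives a number 1.1 degrees C lower from compound 1 to compound 3 (beyond the scatter), so this position does respond to what it carries, although amino and methylsulfonyl stayed within the scatter of each other. The loss is only partial, as compound 3 still gives 4.1 degrees C in this assay.

The compounds shown cannot separate the part played by the carbonyl from that of the cyclopropyl ring, a question that acetyl or a plain methyl on the same nitrogen could help to settle. Nothing available explains why the number falls.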